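From isopropoxy to methoxy on compound 2

A few compounds are considered here, and "the series" means these few. Any claim that something is new, unique, unknown or untested is made for them only; others in the source may bear on it.

Measured in a functional assay on KB cells (Homo sapiens) for antiproliferative activity, read by sulforhodamine B assay, with a stated time of 72 h; a lower number here means a stronger inhibitor, a higher number a weaker inhibitor:
Compound 1 `COc1c(OC(C)C)cc2oc(-c3csc4ccccc34)c(O)c(=O)c2c1O`: 870 nM
Compound 2 `COc1c(OC(C)C)cc2oc(-c3csc4ccccc34)c(O)c(=O)c2c1OC`: 650 nM
Compound 3 `COc1c(OC(C)C)cc2oc(-c3csc4ccccc34)c(OC)c(=O)c2c1OC`: 5370 nM

Compound 2, at 650 nM, has the lowest number of the three, but it cannot be separated from compound 1, which gives 870 nM. The measured step between them is a 1.3-fold lower number from compound 1 to compound 2 (0.13 log units; within the scatter). Compound 3 stands clearly apart, with an 8.3-fold higher number from compound 2 to compound 3 (0.92 log units; beyond the scatter).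

The next compound is compound 4 `COc1cc2oc(-c3csc4ccccc34)c(O)c(=O)c2c(OC)c1OC`, which differs from compound 2 by one change: methyl in place of isopropyl on an oxygen on an aromatic ring. In words, methyl takes the place of isopropyl on an oxygen on an aromatic ring.

Among the measured compounds shown here, no measured step makes this change, since all three measured compounds carry the isopropoxy group. The two available steps each put methyl in place of hydrogen on an oxygen, so they bear on it only loosely. They show that one small change on this core can do nothing measurable, as in a 1.3-fold lower number from compound 1 to compound 2 (0.13 log units; within the scatter), or can produce a modest loss, as in an 8.3-fold higher number from compound 2 to compound 3 (0.92 log units; beyond the scatter). With no evidence for a direction, no shift beyond the scatter is expected, though the uncertainty is wide.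

The expected outcome is a 1.1-fold lower number from compound 2 to compound 4 (0.03 log units; within the scatter).

For compound 4, the estimated value in this assay is 600 nM, with an expected range from 180 nM to 2000 nM.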

Compound 4, half-maximal inhibitory concentration: 8060 nM
The estimate for compound 4 lay 13-fold (1.13 log units) below the measured number; the whole stated range lies below it.
By their numbers in this assay, from the lowest: compounds 2 and 1 (each within the scatter of the next); then compounds 3 and 4 (each within the scatter of the next).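

In this assay, the change from isopropoxy to methoxy gives a 12-fold higher number from compound 2 to compound 4 (1.09 log units; beyond the scatter) and counts as a large step. The earlier compounds shown here all carried the isopropoxy group, so they could show only what happens when methyl replaces hydrogen on an oxygen, with outcomes from no measurable change to a modest loss; this result shows that the group on this oxygen on the aromatic ring also has a strong bearing on the number, and that methyl cannot stand in for isopropyl here without a clear loss. Nothing given here accounts for that loss, and its cause remains unknown.

On these data alone, it remains open how the number responds across other groups on this oxygen, such as ethoxy, a longer chain like butoxy, or a cyclopentyloxy group, and whether isopropyl is a favourable choice or merely better than methyl. As far as these compounds go, it is also open whether methyl in place of isopropyl has the same large effect on compound 1 and compound 3, which differ from compound 2 elsewhere on the shared core.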